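This account rests on a few compounds, and the source may have more. Where it says the series, first, only, none or still open, it means among the compounds named here.

Measured compounds in an assay on FRT cells for positive allosteric modulation of Cystic fibrosis transmembrane conductance regulator variant N1303K (Homo sapiens), in the presence of a further agent that is not named here; on this read-out higher numbers stand for an effect only at larger amounts of compound and lower numbers for an effect already at smaller amounts:
- compound 1 `COc1ccc2[nH]c3c(c2c1)CCNC31CCN(Cc2cc(Cl)ccc2[N+](=O)[O-])CC1` gives 7100 nM
- compound 2 `COc1ccc2[nH]c3c(c2c1)CCNC31CCN(Cc2cccc(F)c2F)CC1` gives 13600 nM
- compound 3 `COc1ccc2[nH]c3c(c2c1)CCNC31CCN(C(C)c2ccccc2)CC1` gives 20000 nM

Compound 3 carries the highest number of the three. Against compound 2 the gap is within the scatter, a 1.5-fold higher number from compound 2 to compound 3 (0.17 log units; within the scatter); against compound 1 it is beyond the scatter, so compound 3 sits apart from compound 1 but not from compound 2.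

Compound 4 `COc1ccc2[nH]c3c(c2c1)CCNC31CCN(Cc2cccnc2)CC1` is the next variation on the shared core: (pyridin-3-yl)methyl in place of 1-phenylethyl on an amine nitrogen in a ring. Among the compounds with values here, two measured steps bear on this change, both swaps of the group on the ring amine nitrogen. The first, a 1.9-fold higher number from compound 1 to compound 2 (0.28 log units; within the scatter), exchanged one substituted aryl ring for another on the saturated chain carbon; the second, a 1.5-fold higher number from compound 2 to compound 3 (0.17 log units; within the scatter), replaced a benzyl-type group with 1-phenylethyl. Neither moved the number beyond the scatter. The step to compound 4 is of the same kind, so in this assay no step beyond the scatter is expected, with a slight lean toward a lower number given that the direction from compound 2 to compound 3 is reversed in part. For compound 4 the expected value is 15000 nM, with a range from 6000 nM to 40000 nM, which means an expected step of a 1.3-fold lower number from compound 3 to compound 4 (0.12 log units; within the scatter).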

Compound 4, half-maximal effective concentration: 17000 nM
Beside the measured number, compound 4's estimate is 1.1-fold (0.05 log units) below it; the range from low to high includes it.
By their numbers in this assay, from the lowest: compounds 1, 2, 4 and 3 (each within the scatter of the next, the first and the last beyond it).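

Working notes on the group on the amine nitrogen in a ring: in this assay, (pyridin-3-yl)methyl, with its ring hetero atom and hydrogen-bond acceptor, reads level with 1-phenylethyl, at a 1.2-fold lower number from compound 3 to compound 4 (0.07 log units; within the scatter), and level with the 2,3-difluorobenzyl group, at a 1.3-fold higher number from compound 2 to compound 4 (0.10 log units; within the scatter), so among these three groups the position does not separate a carbon-only aromatic ring from one with a ring nitrogen. The 5-chloro-2-nitrophenyl group does stand apart from the pyridine, with a 2.4-fold higher number from compound 1 to compound 4 (0.38 log units; beyond the scatter), a modest step that matches its gap to compound 3, although compound 2 stays within the scatter of compound 1 and goes against any clean split of the series. Nothing measured here offers an explanation for these steps.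

Still open, from the compounds shown here alone, is whether the place of the ring nitrogen matters, which pyridin-2-yl or pyridin-4-yl on the same saturated chain carbon would test. Also open, going by these compounds, is how far the chloro and nitro groups of compound 1 each count, and how an aryl ring bearing a carboxylic acid or an amine would read in this assay.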